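This account rests on a few compounds, and the source may have more. Where it says the series, first, only, none or still open, it means among the compounds named here.

Three close relatives of one amide scaffold have been measured in an assay on lysate for inhibition of phosphatidylcholine:ceramide cholinephosphotransferase 2 (Homo sapiens), read by HPLC, with stated times of 30 min and 2 h; on this read-out higher numbers stand for weaker inhibition and lower numbers for stronger inhibition. Compound 1 `O=C(Nc1cccnc1)c1ccccc1OCc1cc(F)ccc1Cl` gives 740 nM, compound 2 `O=C(Nc1cccnc1)c1ccccc1OCc1cc(Cl)ccc1Cl` gives 990 nM, and compound 3 `O=C(Nc1cccnc1)c1ccccc1OCc1c(Cl)cccc1Cl` gives 690 nM. Compound 3 carries the lowest of the three numbers, but its neighbours sit very near it: the step of a 1.1-fold lower number from compound 1 to compound 3 (0.03 log units; within the scatter) and the step of a 1.4-fold lower number from compound 2 to compound 3 (0.16 log units; within the scatter) are both within the scatter, as is the step of a 1.3-fold higher number from compound 1 to compound 2 (0.13 log units; within the scatter). On these three compounds, swapping halogens on the ring that hangs off the ether has not moved this assay beyond its noise.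

Compound 4 `Cc1cccc(C)c1COc1ccccc1C(=O)Nc1cccnc1` takes this one step further: 2,6-dimethylphenyl in place of 2,6-dichlorophenyl on a saturated chain carbon bound to an oxygen on an aromatic ring. Among the measured compounds shown here, no measured step yet exchanges a halogen for a methyl, so the closest guide is the halogen swaps above, which were all small. On that basis the expected change is again modest, a 1.3-fold higher number from compound 3 to compound 4 (0.12 log units; within the scatter), with no firm direction beyond the scatter. The estimated value for compound 4 in this assay is 900 nM, with a plausible range from 400 nM to 2200 nM.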

Compound 4, half-maximal inhibitory concentration: 890 nM
Compound 4: the middle estimate sits 1.0-fold (0.00 log units) above what was measured; the range from low to high includes it.
By their numbers in this assay, from the lowest: compounds 3, 1, 4 and 2 (each within the scatter of the next).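

Compound 4 is the first of these compounds with no halogen on the ring at this position, since 2,6-dimethylphenyl holds 8 carbon atoms where 2,6-dichlorophenyl holds 6 carbon and 2 chlorine. In this assay, this change gives a 1.3-fold higher number from compound 3 to compound 4 (0.11 log units; within the scatter), and the comparisons with the other two rings, a 1.1-fold lower number from compound 2 to compound 4 (0.05 log units; within the scatter) and a 1.2-fold higher number from compound 1 to compound 4 (0.08 log units; within the scatter), also stay within the scatter, so across these four compounds a halogen on this ring is not needed to keep the number in this range. Nothing available here gives a reason for this result.

All four rings are six-membered aromatic rings of carbon only with two or three small substituents, so these compounds say nothing about how the assay would respond to a carboxylic acid or an amine on the ring, or to a longer chain in its place. Among the compounds shown here, since no step among them rises above the scatter, they also leave open which changes at this position, if any, would move the number clearly in either direction.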